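Pyridinyl piperazine amide expected near propyl analogue

This account rests on a few compounds, and the source may have more. Where it says the series, first, only, none or still open, it means among the compounds named here.

Measured so far:
compound 1 `CCCc1ccccc1N1CCN(CCCCCC(=O)NC2CCCc3ccccc32)CC1` — 49.6 nM
compound 2 `CC(C)(C)c1ccccc1N1CCN(CCCCCC(=O)NC2CCCc3ccccc32)CC1` — 538 nM

In an assay on HEK293 cells for displacement of a labelled ligand from 5-hydroxytryptamine receptor 7 (Rattus norvegicus) (a lower number here means a stronger inhibitor, a higher number a weaker inhibitor), compound 1 gives 49.6 nM, and compound 2 gives 538 nM. Compound 2 has the highest number of the two, with an 11-fold higher number from compound 1 to compound 2 (1.04 log units; beyond the scatter). Compound 3 `O=C(CCCCCN1CCN(c2ccccn2)CC1)NC1CCCc2ccccc21` has not been measured; it differs from compound 2 by pyridin-2-yl in place of 2-(tert-butyl)phenyl on an amine nitrogen in a ring. No measured step matches this change, since the only step shown swaps one group for another on the aromatic ring rather than exchanging the ring itself. That step shows that altering what sits on the arene moves the number widely, and removing the tert-butyl group altogether is expected to take compound 3 away from the high number of compound 2. The estimate for compound 3 is therefore 90 nM, between 15 nM and 500 nM, a step of a 6.0-fold lower number from compound 2 to compound 3 (0.78 log units; beyond the scatter).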

Compound 3, inhibition constant: 278 nM
Compound 3: the middle estimate sits 3.1-fold (0.49 log units) below what was measured; the measured number falls inside the stated range.
By their numbers in this assay, from the lowest: compound 1; then compounds 3 and 2 (each within the scatter of the next).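

In this assay, pyridin-2-yl in place of 2-(tert-butyl)phenyl on the amine nitrogen gives a 1.9-fold lower number from compound 2 to compound 3 (0.29 log units; within the scatter), so at this position, exchanging the whole aromatic ring for one with a ring nitrogen leaves these two compounds indistinguishable. Pyridin-2-yl in place of 2-propylphenyl gives a 5.6-fold higher number from compound 1 to compound 3 (0.75 log units; beyond the scatter), which shows that compound 1 stands apart from both other compounds and that the loss of the tert-butyl group alone does not bring the number close to that of compound 1. Nothing measured here explains these numbers.

The compounds shown leave open how much of the gap to compound 1 goes with the ring nitrogen and how much with the missing alkyl group. An unsubstituted phenyl, or a pyridin-2-yl carrying a propyl group, would separate the two.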